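Alkynyl thiazole amides: first untested analogue of the series

The source may hold more compounds than are shown below. What is called first, only, known or untested is meant among the compounds shown, and "the series" means these compounds.

Measured so far:
compound 1, `COc1ccccc1C#Cc1nc2c(s1)C(=O)NCC2`: > 10000 nM
compound 2, `CCC(=O)N1CCc2nc(C#Cc3ccccc3)sc2C1`: > 10000 nM

In an assay on HEK293 cells for positive allosteric modulation of metabotropic glutamate receptor 5 (Homo sapiens), read by FLIPR, with a stated time of 1 h (on this read-out higher numbers stand for an effect only at larger amounts of compound and lower numbers for an effect already at smaller amounts), compound 1 gives > 10000 nM, which is a limit of the assay and not a number. In this assay compound 2 gives > 10000 nM, again only a limit. Both values therefore sit at the limit of > 10000 nM in this assay, at which 2 of the 2 values shown sit, and compound 2 stands on no measured number at all; nothing within the resolved range of this assay is known for it. Among the measured compounds shown here, no step between measured compounds can be computed, since compounds 1 and 2 differ in more than one place.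

For the measured compounds named here, compound 3, `Cc1cccc(C(=O)N2CCc3nc(C#Cc4ccccc4)sc3C2)n1`, is the first untested member. It differs from compound 2 as 6-methylpyridin-2-yl in place of ethyl on a carbonyl carbon. With compound 2 at a limit, the step cannot be sized against anything measured; the expectation rests only on the change itself. The step from compound 2 to compound 3, an at least 3.3-fold lower number from compound 2 to compound 3 (0.52 log units; beyond the scatter), is expected to run downward in this assay, toward an effect at smaller amounts, though a further limit remains a real possibility. Compound 3 is estimated at 3000 nM, with a range from 300 nM to 10000 nM.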

Compound 3, half-maximal effective concentration: 160 nM
For compound 3 the middle estimate is 19-fold (1.27 log units) above the measured one; measured number below the stated range.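

The amide carbonyl carbon is a position that can carry activity in this assay: with 6-methylpyridin-2-yl in place of ethyl on that carbon, the series shows an at least 62-fold lower number from compound 2 to compound 3 (1.79 log units; beyond the scatter). As far as these compounds go, compound 2 gives > 10000 nM, which is a limit of the assay and not a number, so the true size of this step stays unknown and only its lower bound is read. Compound 3 is also the first compound shown to give a resolved number, and the change that brings this about enters a six-membered aromatic ring with one hetero atom where the ethyl had no ring, while the other values shown remain at the limit: the limit of > 10000 nM in this assay, at which 2 of the 3 values shown sit.

From the compounds shown here alone, this single change does not separate the contributions of the ring, its nitrogen and its methyl, so it remains open whether a plain phenyl, an unsubstituted pyridin-2-yl or a longer alkyl chain such as butyl on the same carbonyl carbon would give a comparable number. Going by these compounds, it also remains open how the methyl on the pyridine ring compares with a methoxy or a chlorine in its place, and whether the terminal phenyl on the alkyne tolerates any substituent when this amide is kept.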